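The source may report more compounds than this note shows. Statements on the series, on what has been measured and on what is new or still open speak of the compounds shown alone.

Measured so far:
compound 1 `COc1cc(-c2ccnc3cc(-c4ccc(Cl)cc4)nn23)cc(OC)c1OC` gives 2320 nM;
compound 2 `Cn1ccc2cc(-c3cc4nccc(-c5ccc(F)cc5)n4n3)ccc21` gives 4580 nM;
compound 3 `COc1cc(-c2cc3nccc(-c4c[nH]c5ccccc45)n3n2)cc(OC)c1OC` reaches only the assay limit, > 10000 nM.

In a functional assay on MCF7 cells (Homo sapiens) for inhibition, read by CCK-8 assay, with a stated time of 48 h (on this read-out lower numbers stand for stronger inhibition and higher numbers for weaker inhibition), compound 1 holds the lowest of the two numbers shown, while compound 2 sits within the scatter of it. Compound 3 gives a limit rather than a number (the limit of > 10000 nM in this assay, at which 1 of the 3 values shown sits). Compound 4 `COc1cc(-c2ccnc3cc(-c4ccc5ccn(C)c5c4)nn23)cc(OC)c1OC` has not yet been measured; it differs from compound 1 in one place (1-methyl-1H-indol-6-yl in place of 4-chlorophenyl on an aromatic carbon). Among the compounds with values here, no measured step between two compounds differing only there exists, so the expected size rests on compounds 2 and 3 alone, and a modest weakening, not far beyond the scatter, is expected as a 1.5-fold higher number from compound 1 to compound 4 (0.18 log units; within the scatter). Compound 4 is therefore estimated at 3500 nM, within 1200 nM to 10000 nM.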

Compound 4, half-maximal inhibitory concentration: 74 nM
Compound 4: middle estimate off by 47-fold (1.67 log units), on the high side, outside the stated range (below it).
By their numbers in this assay, from the lowest: compound 4; then compounds 1 and 2 (each within the scatter of the next). At a limit, above all of these: compound 3.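

In this assay, this aromatic carbon of the five-membered ring, next to the ring nitrogen, proves far from indifferent to its substituent: 1-methyl-1H-indol-6-yl in place of 4-chlorophenyl gives a 31-fold lower number from compound 1 to compound 4 (1.50 log units; beyond the scatter), the first step seen at this position. The result shows that a larger two-ring group is accepted here and can go with much stronger inhibition. Nothing shown accounts for the size of this step.

It remains open whether the methyl on the indole nitrogen contributes, since the unmethylated 1H-indol-6-yl does not appear among these compounds. Whether a naphthyl group or a phenyl ring carrying an amine could match the indole also stays unresolved.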